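Swapping the benzylic aryl group in nitrofuran triazole amides

The compounds below may be only part of what the source reports. "The series", "measured", "known", "first", "only" and "open" are said of these compounds alone.

Measured compounds:
- compound 1, `COc1ccc(Cn2cc(CNC(=O)c3ccc([N+](=O)[O-])o3)nn2)cc1O`: 174000 nM
- compound 2, `O=C(NCc1cn(Cc2ccc([N+](=O)[O-])cc2)nn1)c1ccc([N+](=O)[O-])o1`: 291000 nM
- compound 3, `O=C(NCc1cn(Cc2ccc(F)c(Cl)c2)nn1)c1ccc([N+](=O)[O-])o1`: 344000 nM

These three compounds share one core and differ only in the aryl group on a saturated chain carbon bound to an aromatic nitrogen. In an ADME assay on Vero cells (Chlorocebus sabaeus) for cytotoxicity (a lower number here means a stronger inhibitor, a higher number a weaker inhibitor), compound 1 gives 174000 nM, the lowest of the three numbers, yet both other compounds lie within the usual scatter of it: a 1.7-fold higher number from compound 1 to compound 2 (0.22 log units; within the scatter) and a 2.0-fold higher number from compound 1 to compound 3 (0.30 log units; within the scatter). Likewise a 1.2-fold higher number from compound 2 to compound 3 (0.07 log units; within the scatter).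

Compound 4, `O=C(NCc1cn(Cc2cccc([N+](=O)[O-])c2)nn1)c1ccc([N+](=O)[O-])o1`, has not yet been measured. Its change from compound 1 is 3-nitrophenyl in place of 3-hydroxy-4-methoxyphenyl on a saturated chain carbon bound to an aromatic nitrogen. Compound 2 carries a nitro group on the same ring in a different position, and the measured steps bear on this change: all three steps among compounds 1, 2 and 3 stayed within the scatter. No step beyond the scatter is therefore expected in this assay for compound 4, and the expected step is a 1.4-fold higher number from compound 1 to compound 4 (0.16 log units; within the scatter). The estimate for compound 4 is 250000 nM, within a range from 120000 nM to 500000 nM.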

Compound 4, half-maximal inhibitory concentration: 326000 nM
Compound 4: the middle estimate sits 1.3-fold (0.12 log units) below what was measured; measured number inside the range.
By their numbers in this assay, from the lowest: compounds 1, 2, 4 and 3 (each within the scatter of the next).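

In this assay this position again shows no step beyond the scatter: there is a 1.9-fold higher number from compound 1 to compound 4 (0.27 log units; within the scatter) and also a 1.1-fold lower number from compound 3 to compound 4 (0.02 log units; within the scatter) for the two new comparisons across different aryl groups. Among these compounds, what the earlier compounds did not show is that the place of the nitro group on the ring makes no readable difference either, with a 1.1-fold higher number from compound 2 to compound 4 (0.05 log units; within the scatter) between the two nitro isomers, so 3-nitrophenyl and 4-nitrophenyl cannot be told apart here. No evidence is available on why these four aryl groups read alike.

Going by these compounds, all four carry a six-membered aromatic ring of carbon only, so it stays open whether an amine or a carboxylic acid on that ring, or a longer chain at this place, would give a step beyond the scatter. On these data alone, whether the same holds in any other assay also stays open.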